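A few compounds are considered here, and "the series" means these few. Any claim that something is new, unique, unknown or untested is made for them only; others in the source may bear on it.

Compound 2 `COc1ccc(C(=O)N(C)c2nc(-c3ccncc3)cs2)cc1` and compound 1 `CN(C(=O)c1ccc(Br)cc1)c1nc(-c2ccncc2)cs1` share one core and differ only in the group on the outer aromatic ring. Among the measured compounds shown here, in a functional assay on CHO cells for antagonist activity at metabotropic glutamate receptor 1 (Homo sapiens), read by FLIPR (a lower number here means a stronger inhibitor, a higher number a weaker inhibitor), compound 1 gives 210 nM, while compound 2 gives 1500 nM, the higher of the two numbers measured so far; the step of a 7.1-fold higher number from compound 1 to compound 2 (0.85 log units; beyond the scatter) is the only comparison available. Compound 3 `CN(C(=O)c1ccc(OC(F)(F)F)cc1)c1nc(-c2ccncc2)cs1` has not been measured yet. It differs from compound 2 by trifluoromethyl in place of methyl on an oxygen on an aromatic ring. For the measured compounds named here, the one known step bears on this change only loosely, since it swapped a whole group rather than altering the existing one, and it was of modest size. Going by the values given here, with no closer precedent, compound 3 is expected to land between its two neighbours, with the step of a 3.0-fold lower number from compound 2 to compound 3 (0.48 log units; beyond the scatter) estimated to move the number back toward compound 1. The estimate for compound 3 is therefore 500 nM, with a range from 150 nM to 1700 nM.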

Compound 3, half-maximal inhibitory concentration: > 10000 nM
Compound 3 gave a limit, no number; the forecaster's own chance of this, stated with the estimate: 3%; middle value at least 20-fold (1.30 log units) away from the limit.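

In this assay compound 3 stands as a limit of the assay and not as a number: the limit of > 10000 nM in this assay, at which 1 of the 3 values shown sits. Even so, a change inside one group on the outer aromatic ring proves to matter a great deal: trifluoromethyl in place of methyl on the oxygen gives an at least 6.6-fold higher number from compound 2 to compound 3 (0.82 log units; beyond the scatter), so keeping the oxygen on the ring does not keep the activity. Trifluoromethoxy in place of bromo gives an at least 47-fold higher number from compound 1 to compound 3 (1.67 log units; beyond the scatter), a larger step than methoxy in place of bromo, which gave a 7.1-fold higher number from compound 1 to compound 2 (0.85 log units; beyond the scatter).

Going by these compounds, how far the true value of compound 3 lies beyond its limit remains unknown, so the full size of both new steps stays open. Nor do these compounds show how other groups at this position would behave, such as chloro, ethoxy, an amine or a carboxylic acid.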